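Compound 1 to compound 3: a methoxy group moved

The source may report more compounds than this note shows. Statements on the series, on what has been measured and on what is new or still open speak of the compounds shown alone.

Among the compounds with values here, of the two numbers so far in a functional assay on PC-3 cells (Homo sapiens) for inhibition, read by sulforhodamine B assay, with a stated time of 48 h, tested at 50 uM (a higher number here means more inhibition of growth at the concentration tested, a lower number less inhibition of growth), none stands above compound 1 `COc1ccccc1/C=C/C(=O)/C=C/c1ccc(OCc2cn(CCOc3cc(=O)oc4ccccc34)nn2)c(OC)c1`, which gives 11%. Compound 2 `COc1cc(/C=C/C(=O)/C=C/c2cccc3ccccc23)ccc1OCc1cn(CCCOc2cc(=O)oc3ccccc23)nn1` gives 8% in this assay, a number within the scatter of compound 1, so the two are not ranked. Compound 3 `COc1cccc(/C=C/C(=O)/C=C/c2ccc(OCc3cn(CCOc4cc(=O)oc5ccccc45)nn3)c(OC)c2)c1` differs from compound 1 by 3-methoxyphenyl in place of 2-methoxyphenyl on a double-bonded chain carbon bound to a double-bonded chain carbon. Within the data shown here, no step between measured compounds is known here, so the expected step of a number 1 percentage points lower from compound 1 to compound 3 (within the scatter) is small, in no direction beyond the scatter. Compound 3 is estimated at 10% in this assay, within 0% to 25%.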

Compound 3, percent growth inhibition at one concentration: 13%
The estimate for compound 3 lay 3 percentage points below the measured number; the range from low to high includes it.
By their numbers in this assay, from the lowest: compounds 2, 1 and 3 (each within the scatter of the next).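

Read in this assay, 3-methoxyphenyl in place of 2-methoxyphenyl on a double-bonded chain carbon bound to a double-bonded chain carbon gives a number 2 percentage points higher from compound 1 to compound 3 (within the scatter) and does not separate the two compounds. Within the data shown here, this is the first single-place step, and it shows that this rearrangement of the same atoms does not rank the pair. No available data bear on the reason for this result.

Open, on these data alone, is whether an amine or a carboxylic acid on this aromatic ring, in place of methoxy, would give a step beyond the scatter. Also open, as far as these compounds go, is how a longer chain in place of methoxy would read.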